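This account rests on a few compounds, and the source may have more. Where it says the series, first, only, none or still open, it means among the compounds named here.

For the measured compounds named here, compound 1 `COc1ccc(/C=C\c2cc(OC)c(OC)c(OC)c2)cc1OCc1ccc(C=O)cc1` carries a formyl group on the benzyl ether, and in a functional assay on B16-F10 cells (Mus musculus) for antiproliferative activity, read by CCK-8 assay, with a stated time of 48 h (on this read-out lower numbers stand for stronger inhibition and higher numbers for weaker inhibition), compound 1 gives 4200 nM, the only number among the three values at hand. Compound 2 `COc1ccc(/C=C\c2cc(OC)c(OC)c(OC)c2)cc1OCc1ccc(CN2CC(C(=O)O)C2)cc1` has (3-carboxyazetidin-1-yl)methyl in place of formyl, and in this assay compound 2 reaches > 10000 nM, which is a limit of the assay and not a number. Compound 3 `COc1ccc(/C=C\c2cc(OC)c(OC)c(OC)c2)cc1OCc1ccc(CN2CC[C@H](O)C2)cc1` has (3-hydroxypyrrolidin-1-yl)methyl in place of formyl, and in this assay compound 3 likewise reaches > 10000 nM, again a limit. Both steps away from compound 1 therefore read as an at least 2.3-fold higher number from compound 1 to compound 2 (0.37 log units; beyond the scatter) and an at least 2.3-fold higher number from compound 1 to compound 3 (0.37 log units; beyond the scatter), while a step that the two limits leave unreadable from compound 2 to compound 3 cannot be sized because of the limit of > 10000 nM in this assay, at which 2 of the 3 values shown sit.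

Compound 4 `COc1ccc(/C=C\c2cc(OC)c(OC)c(OC)c2)cc1OCc1ccc(CNCCN(C)C)cc1` differs from compound 1 by ((2-(dimethylamino)ethyl)amino)methyl in place of formyl on an aromatic carbon. The two earlier amine replacements of formyl both moved the value past the limit, so a similar step is expected here. The step from compound 1 to compound 4 is estimated at a 2.9-fold higher number from compound 1 to compound 4 (0.46 log units; beyond the scatter). Compound 4 is expected to give about 12000 nM in this assay, with a range from 4000 nM to 40000 nM.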

Compound 4, half-maximal inhibitory concentration: > 10000 nM
Compound 4 was reported as a limit; the forecaster's own chance of this, stated with the estimate: 60%; the middle value does not contradict the limit.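

In this assay, putting ((2-(dimethylamino)ethyl)amino)methyl in place of formyl gives an at least 2.3-fold higher number from compound 1 to compound 4 (0.37 log units; beyond the scatter). This group has no ring, whereas the replacements in compound 2 and compound 3 both did, so the same direction of change at this place, on an aromatic carbon para to a large group, now holds for an open chain as well, and none of the three replacements goes against it. The steps among compound 2, compound 3 and compound 4 cannot be read because all three values are limits of the assay: the limit of > 10000 nM in this assay, at which 3 of the 4 values shown sit.

How far each of these compounds lies past that limit remains open. So does how a hydroxymethyl group, a carboxylic acid or a plain aminomethyl group would read at this same place, without the longer amine chain or ring.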